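The compounds below may be only part of what the source reports. "The series", "measured", "known", "first", "only" and "open" are said of these compounds alone.

Compound 3 `COc1ccc(F)cc1CNCCCNc1ccnc2cc(Oc3ccc(Cl)cc3)ccc12` is one of three compounds tested in an ADME assay for permeability, using PAMPA, with a stated time of 30 min, at pH 7.4 (on this read-out higher numbers stand for higher permeability and lower numbers for lower permeability), where compound 3 gives 317 10^-6 cm/s. Compound 1 `COc1ccc(Oc2ccc3c(NCCCNCc4cc(F)ccc4OC)ccnc3c2)cc1` gives 317 10^-6 cm/s and compound 2 `CN(C)c1cccc(Oc2ccc3c(NCCCNCc4ccco4)ccnc3c2)c1` gives 317 10^-6 cm/s, so compound 3 stands level with both within the scatter of this assay. For the measured compounds named here, the only single change among the measured compounds, no change at the digits printed from compound 1 to compound 3 (within the scatter), left the read-out unchanged. Compound 4 `COc1ccc(F)cc1CNCCCNc1ccnc2cc(Oc3cccc(N(C)C)c3)ccc12` differs from compound 3 by 3-(dimethylamino)phenyl in place of 4-chlorophenyl on an oxygen on an aromatic ring. Going by the values given here, compound 2 carries the same 3-(dimethylamino)phenyl group but differs in more than one place, so its value shows only that this group is compatible with a high reading. The step is therefore expected to be no change at the digits printed from compound 3 to compound 4 (within the scatter), within the scatter. Compound 4 is estimated at 317 10^-6 cm/s, between 150 10^-6 cm/s and 640 10^-6 cm/s.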

Compound 4, apparent permeability: 317 10^-6 cm/s
Compound 4: middle estimate and measured number agree at the digits printed; measured number inside the range.
By their numbers in this assay, from the lowest: compounds 1, 2, 3 and 4 (each within the scatter of the next).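

In this assay, a second group on an oxygen on an aromatic ring now gives a direct comparison with 4-chlorophenyl (a step of no change at the digits printed from compound 3 to compound 4 (within the scatter)), and 3-(dimethylamino)phenyl in place of 4-methoxyphenyl reads the same way (no change at the digits printed from compound 1 to compound 4 (within the scatter)). For the compounds shown here, a first single change on a saturated chain carbon bound to an amine nitrogen, 5-fluoro-2-methoxyphenyl in place of furan-2-yl, also leaves the numbers level (no change at the digits printed from compound 2 to compound 4 (within the scatter)). No measurement offered here explains why these values coincide. Going by these compounds, whether a group of another kind at this place, such as a carboxylic acid, would keep the reading level remains open.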